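Fluorophenyl amides on a diaryl pyrazole core: moving the fluorine

The compounds below may be only part of what the source reports. "The series", "measured", "known", "first", "only" and "open" are said of these compounds alone.

Measured compounds in an assay on CHO cells with metabotropic glutamate receptor 5 (Homo sapiens) as the target; a higher number here means that more compound is needed for the effect, a lower number that less compound is needed:
compound 1 `O=C(Nc1cc(-c2ccccc2)nn1-c1ccccc1)c1ccc(F)c(F)c1` gives 10 nM
compound 2 `O=C(Nc1cc(-c2ccccc2)nn1-c1ccccc1)c1ccccn1` gives 290 nM
compound 3 `O=C(Nc1cc(-c2ccccc2)nn1-c1ccccc1)c1ccccc1F` gives 75 nM

Compound 3 holds the second highest number of the three; compound 2 lies closer to it, with a 3.9-fold lower number from compound 2 to compound 3 (0.59 log units; beyond the scatter), while compound 1 lies further off, with a 7.5-fold higher number from compound 1 to compound 3 (0.88 log units; beyond the scatter). All three share the same core, and only the group on the carbonyl carbon changes.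

Compound 4 `O=C(Nc1cc(-c2ccccc2)nn1-c1ccccc1)c1cccc(F)c1` differs from compound 3 in that place: 3-fluorophenyl in place of 2-fluorophenyl on a carbonyl carbon. Within the data shown here, no measured step moves a fluorine within the phenyl ring; the measured steps either swap the ring for pyridin-2-yl, as in a 29-fold higher number from compound 1 to compound 2 (1.46 log units; beyond the scatter), or remove one fluorine, as in a 7.5-fold higher number from compound 1 to compound 3 (0.88 log units; beyond the scatter). Compound 1, which also carries a fluorine at position 3 of its ring, gives 10 nM, so a lower number than compound 3 is expected for compound 4, but the size is uncertain and a step within the scatter cannot be excluded.

Compound 4 is therefore estimated at 30 nM in this assay, with a range from 10 nM to 100 nM, which means an expected step of a 2.5-fold lower number from compound 3 to compound 4 (0.40 log units; beyond the scatter).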

Compound 4, half-maximal effective concentration: 20 nM
Estimate against measurement, compound 4: 1.5-fold (0.18 log units) above, within the range that was stated.
By their numbers in this assay, from the lowest: compounds 1 and 4 (each within the scatter of the next); then compound 3; then compound 2.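

In this assay, the change from 2-fluorophenyl to 3-fluorophenyl alone gives a 3.8-fold lower number from compound 3 to compound 4 (0.57 log units; beyond the scatter), so with the same atoms in both groups, the place of the fluorine on the ring matters at this position. Hydrogen in place of fluoro gives a 2.0-fold higher number from compound 1 to compound 4 (0.30 log units; within the scatter), so the second fluorine of the 3,4-difluorophenyl group brings no change that stands clear of the scatter, while 3-fluorophenyl in place of pyridin-2-yl gives a 15-fold lower number from compound 2 to compound 4 (1.16 log units; beyond the scatter). Nothing available here explains these steps.

Going by these compounds, whether 4-fluorophenyl behaves like 3-fluorophenyl remains open, as does whether chloro, methoxy or nitrile can replace the fluorine on the same ring. Also open, on these data alone, is how any such amide responds to substituents on the two phenyl groups of the shared core.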